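This account rests on a few compounds, and the source may have more. Where it says the series, first, only, none or still open, it means among the compounds named here.

Compound 1 has the structure `CSc1ccc(CNc2nc(SC)nc3ncccc23)cc1` and, in a functional assay on HT-29 cells (Homo sapiens) for cytotoxicity, read by MTT assay, with a stated time of 72 h (on this read-out lower numbers stand for higher toxicity in this test and higher numbers for lower toxicity in this test), compound 1 gives 8750 nM. Within the numbers available, compound 1 is the only compound with a measured number at all. Compound 2, with the structure `CCCCC[Se]c1nc(NCc2ccccc2)c2ccccc2n1`, is reported in this assay only as a limit of the assay, > 100000 nM, and not as a number; this is the limit of > 100000 nM in this assay, at which 1 of the 2 values shown sits. Among the compounds with values here, no step between two measured compounds can be computed from these two entries, so nothing is yet known about how a single change of a group shifts this assay.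

Compound 3, with the structure `COc1ccc(CNc2nc(SC)nc3ncccc23)cc1`, has not been measured. It differs from compound 1 by methoxy in place of methylsulfanyl on an aromatic carbon, para to a large group. Within the data shown here, since no measured step is available to guide the size, the expected step from compound 1 to compound 3 in this assay is a 1.4-fold higher number from compound 1 to compound 3 (0.14 log units; within the scatter), which is not expected to exceed the usual scatter. Compound 3 is therefore estimated to give 12000 nM in this assay, within a range from 4000 nM to 40000 nM.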

Compound 3, concentration lethal to 50% of the cells: > 100000 nM
Compound 3 ended at the assay's limit; the forecaster's own chance of this, stated with the estimate: 10%; middle value at least 8.3-fold (0.92 log units) from the limit.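

In this assay, replacing methylsulfanyl with methoxy on the aromatic carbon, para to a large group, produces an at least 11-fold higher number from compound 1 to compound 3 (1.05 log units; beyond the scatter). Within the data shown here, this is the first step that can be read, and it shows that this position is sensitive to the change: one sulfur is exchanged for one oxygen, while the counts of heavy atoms, hydrogen-bond donors and hydrogen-bond acceptors stay the same, and the measured number of compound 1 is lost. Compound 3 now stands at the same limit of the assay as compound 2: the limit of > 100000 nM in this assay, at which 2 of the 3 values shown sit.

As far as these compounds go, how far the true value of compound 3 lies beyond that limit remains open. So does whether ethylsulfanyl, a chlorine atom or an amine at this position would keep a measurable number like that of compound 1.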